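Fluorophenyl series: cytotoxicity working notes

This account rests on a few compounds, and the source may have more. Where it says the series, first, only, none or still open, it means among the compounds named here.

Two members of this set have been run in a toxicity assay on HepG2 2.2.15 cells (Homo sapiens) for cytotoxicity, read by CCK-8 assay, with a stated time of 8 days; on this read-out lower numbers stand for higher toxicity in this test and higher numbers for lower toxicity in this test. Compound 1 `CCOC(=O)c1cn(-c2ccc([N+](=O)[O-])cc2)nc1CC(C)C` carries a nitrophenyl group on the ring nitrogen of the shared core; in this assay compound 1 returns only a limit, > 100000 nM, not a number. Compound 2 `CCOC(=O)c1cn(-c2ccccc2F)nc1CC(C)C` carries 2-fluorophenyl at that same nitrogen; in this assay compound 2 likewise returns only a limit, > 100000 nM. Compound 2 thus stands at the upper edge of what this assay reports, and so does the other value in hand: the limit of > 100000 nM in this assay, at which 2 of the 2 values shown sit. For the measured compounds named here, no pair of measured compounds differing in a single place exists here, so no measured step gives a direction or a size.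

Compound 3 `CCOC(=O)c1cn(-c2ccc(F)cc2)nc1CC(C)C` differs from compound 2 in one respect: 4-fluorophenyl in place of 2-fluorophenyl on an aromatic nitrogen. The same atoms are kept and only rejoined. Going by the values given here, both values so far sit at the reporting limit, which leaves no room for an upward read. The expected step in this assay, a step that the limit leaves unreadable from compound 2 to compound 3, is none beyond the scatter. Compound 3 is therefore expected to give 150000 nM in this assay, within 50000 nM to 500000 nM, and most likely to be reported again as a limit rather than a number.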

Compound 3, half-maximal cytotoxic concentration: > 100000 nM
Compound 3 was reported as a limit; the forecaster's own chance of this, stated with the estimate: 85%; the middle value lies beyond the limit too.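

In this assay compound 3 gives > 100000 nM, a limit and not a number. The steps from compound 1 and from compound 2 to compound 3 cannot be read, because all the results sit at the same limit: the limit of > 100000 nM in this assay, at which 3 of the 3 values shown sit.

Left open is whether these three compounds differ at all in this assay.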